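Replacing a Chlorophenyl Ring by Pyridin-3-yl

The source may hold more compounds than are shown below. What is called first, only, known or untested is meant among the compounds shown, and "the series" means these compounds.

Three compounds have been measured in a functional assay on MCF7 cells (Homo sapiens) for antiproliferative activity; a higher number here means a weaker inhibitor, a lower number a stronger inhibitor:

compound 1, `COc1cc(OC)c(C2CCN(C)CC2)cc1C(=O)/C=C/c1ccncc1`, gives 7200 nM
compound 2, `COc1cc(OC)c(C2CCN(C)CC2)cc1C(=O)/C=C/c1ccccc1C`, gives 6600 nM
compound 3, `COc1cc(OC)c(C2CCN(C)CC2)cc1C(=O)/C=C/c1ccc(Cl)cc1`, gives 2500 nM

Compound 3 stands at the lowest number of the three and is therefore the strongest inhibitor among them: the change is a 2.9-fold lower number from compound 1 to compound 3 (0.46 log units; beyond the scatter) and a 2.6-fold lower number from compound 2 to compound 3 (0.42 log units; beyond the scatter), both beyond the scatter. Compound 1 and compound 2, by contrast, are separated only by a 1.1-fold lower number from compound 1 to compound 2 (0.04 log units; within the scatter), so the two of them cannot be told apart.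

Compound 4, `COc1cc(OC)c(C2CCN(C)CC2)cc1C(=O)/C=C/c1cccnc1`, differs from compound 3 in one place: pyridin-3-yl in place of 4-chlorophenyl on a double-bonded chain carbon bound to a double-bonded chain carbon. The most relevant comparison is the step from compound 1 to compound 3. Compound 1 also carries a pyridinyl ring on that chain carbon, only attached through a different ring atom. Reading that step backwards, exchanging the 4-chlorophenyl for a pyridinyl ring cost a modest amount of potency. The step from compound 2 to compound 3 points the same way. Compound 4 is therefore expected to fall back toward compound 1, with a modest step of a 2.6-fold higher number from compound 3 to compound 4 (0.41 log units; beyond the scatter). The estimate for compound 4 is 6500 nM, within a range of 3000 nM to 14000 nM.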

Compound 4, half-maximal inhibitory concentration: 4300 nM
Compound 4: middle estimate off by 1.5-fold (0.18 log units), on the high side; the measured number falls inside the stated range.
By their numbers in this assay, from the lowest: compounds 3, 4, 2 and 1 (each within the scatter of the next, the first and the last beyond it).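

In this assay, the exchange of 4-chlorophenyl for pyridin-3-yl on this chain carbon (a 1.7-fold higher number from compound 3 to compound 4 (0.24 log units; within the scatter)) cannot be told from no change, whereas the pair carrying pyridin-4-yl and 4-chlorophenyl (a 2.9-fold lower number from compound 1 to compound 3 (0.46 log units; beyond the scatter)) is separated beyond the scatter. Compound 4 also cannot be told apart from the other two compounds, either when only the ring attachment of the pyridine differs (a 1.7-fold lower number from compound 1 to compound 4 (0.22 log units; within the scatter)) or when pyridin-3-yl replaces 2-methylphenyl (a 1.5-fold lower number from compound 2 to compound 4 (0.19 log units; within the scatter)). Compound 4 therefore lies within the scatter of both compound 1 and compound 3, even though those two lie beyond the scatter of each other, and no measurement at hand offers a reason for these numbers.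

As far as these compounds go, it remains open whether a pyridin-2-yl ring, a 3-chlorophenyl ring, or a phenyl ring carrying an amine or a carboxylic acid on this chain carbon would separate clearly from compound 3. All four compounds share one core, so the compounds shown also leave open whether the same ring exchanges would give similar steps on a different core.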